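The source may hold more compounds than are shown below. What is called first, only, known or untested is meant among the compounds shown, and "the series" means these compounds.

Measured in an ADME assay on HepG2 2.2.15 cells (Homo sapiens) for cytotoxicity, read by MTT assay; a higher number here means that more compound is tolerated, a lower number that less compound is tolerated:

compound 1 `C=C1CC[C@@H]2[C@](C)(COC(=O)/C=C/c3cc(OC)c(OC)c(OC)c3)[C@H](O)CC[C@@]2(C)[C@@H]1/C=C/C1=CCOC1=O` gives > 1700000 nM (a limit)
compound 2 `C=C1CC[C@@H]2[C@](C)(CO)[C@H](OC(=O)/C=C/c3cc(OC)c(OC)c(OC)c3)CC[C@@]2(C)[C@@H]1C/C=C1\C=COC1=O` gives 211000 nM
compound 3 `C=C1CC[C@@H]2[C@](C)(CO)[C@H](OC(=O)c3cccs3)CC[C@@]2(C)[C@@H]1C/C=C1\C=COC1=O` gives 257000 nM

The reading for compound 1, > 1700000 nM, is a limit of the assay and not a number. That leaves two true numbers to work with. Compound 2 gives 211000 nM and compound 3 gives 257000 nM, and these two values lie within the scatter of each other. Compound 3 therefore stands level with compound 2 in this assay, with no real separation between them.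

The next compound is compound 4 `C=C1CC[C@@H]2[C@](C)(CO)[C@H](OC(=O)CCCC)CC[C@@]2(C)[C@@H]1C/C=C1\C=COC1=O`, which has not yet been measured. It carries butyl in place of thiophen-2-yl on a carbonyl carbon, so the five-membered aromatic ring leaves and no ring enters. Among the measured compounds shown here, no measured step of this kind is available as a guide. For the measured compounds named here, the only numbers to lean on are those of compound 3 at 257000 nM and compound 2 at 211000 nM, so no shift in either direction is expected beyond the scatter. The expected change is a 1.0-fold lower number from compound 3 to compound 4 (0.01 log units; within the scatter), a small estimated step. For compound 4 the estimated value in this assay is 250000 nM, with an expected range from 110000 nM to 600000 nM.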

Compound 4, half-maximal cytotoxic concentration: 126000 nM
Beside the measured number, compound 4's estimate is 2.0-fold (0.30 log units) above it, and the stated range covers the measured number.
By their numbers in this assay, from the lowest: compounds 4, 2 and 3 (each within the scatter of the next, the first and the last beyond it). At a limit, above all of these: compound 1.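

Placed on a carbonyl carbon whose other neighbour is the ester oxygen, butyl in place of thiophen-2-yl gives a 2.0-fold lower number from compound 3 to compound 4 (0.31 log units; beyond the scatter) in this assay, so the group at this position can move the number beyond the scatter, although only modestly. The earlier compounds shown here could not show this: compound 2 at 211000 nM and compound 3 at 257000 nM lie within the scatter of each other, and no single-place step had yet been available. Nothing measured here bears on the cause of this step, so the shift stands as an observation without an explanation.

The compounds shown leave open whether the lower number goes with the loss of the five-membered aromatic ring or with the butyl chain that enters, and one pair cannot separate the two. A phenyl ring, a longer chain or a chain carrying an amine at this same carbonyl carbon would show whether the number follows the ring, the chain length or neither.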